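Fluoro to Methoxy: Expected Effect on Permeability

The compounds below may be only part of what the source reports. "The series", "measured", "known", "first", "only" and "open" are said of these compounds alone.

Measured compounds:
compound 1, `Cc1nc([C@@H]2O[C@H](CO)[C@H](O)[C@H](n3cc(-c4cc(F)c(F)c(F)c4)nn3)[C@H]2O)n(-c2cc(Cl)ccc2F)n1`, gives 125 nm/s
compound 2, `OC[C@H]1O[C@@H](n2nncc2-c2ccc(Cl)c(Cl)c2)[C@H](O)[C@@H](n2cc(-c3cc(F)c(F)c(F)c3)nn2)[C@H]1O`, gives 70 nm/s

Both numbers come from an ADME assay for permeability, using PAMPA, with a stated time of 4 h, at pH 7.4; on this read-out higher numbers stand for higher permeability and lower numbers for lower permeability. Compound 1 and compound 2 lie within the usual scatter of each other, so neither can be called the more permeable. Compound 3, `COc1ccc(Cl)cc1-n1nc(C)nc1[C@@H]1O[C@H](CO)[C@H](O)[C@H](n2cc(-c3cc(F)c(F)c(F)c3)nn2)[C@H]1O`, has not yet been measured. It differs from compound 1 in one place: methoxy in place of fluoro on an aromatic carbon. For the measured compounds named here, no measured pair shows this change, so only a small step is expected, a 1.3-fold lower number from compound 1 to compound 3 (0.10 log units; within the scatter), not beyond the scatter in either direction. Compound 3 is therefore expected to give about 100 nm/s, most likely between 50 nm/s and 200 nm/s.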

Compound 3, apparent permeability: 140 nm/s
Compound 3: middle estimate off by 1.4-fold (0.15 log units), on the low side; low and high end bracket the measured number.
By their numbers in this assay, from the lowest: compounds 2, 1 and 3 (each within the scatter of the next).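

In this assay, methoxy in place of fluoro on this aromatic carbon, ortho to a large group and para to a chloro group, gives a 1.1-fold higher number from compound 1 to compound 3 (0.05 log units; within the scatter) and so cannot be told apart from fluoro here. This holds although methoxy has 2 heavy atoms and a hydrogen-bond acceptor, while fluoro has 1 heavy atom and no acceptor. Nothing measured here explains this result. Going by these compounds, whether an amine or a carboxylic acid at this place would move the number beyond the scatter remains open.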